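A Methoxyphenyl for Difluorophenyl Swap in a 5-Lipoxygenase Series

This account rests on a few compounds, and the source may have more. Where it says the series, first, only, none or still open, it means among the compounds named here.

Compound 1 `CCC(Sc1nc(Cl)cc(Nc2nc(-c3ccc(Cl)cc3)cs2)n1)C(=O)O`: 6600 nM
Compound 2 `CCCCCCC(Sc1nc(Cl)cc(Nc2nc(-c3ccc(F)cc3F)cs2)n1)C(=O)O`: 2500 nM

Among the compounds with values here, in an assay for inhibition of Polyunsaturated fatty acid 5-lipoxygenase (Homo sapiens), read by HPLC, with a stated time of 10 min (a higher number here means a weaker inhibitor, a lower number a stronger inhibitor), compound 2 holds the lower of the two numbers, and compound 1 lies beyond the usual scatter above it; the two compounds differ in more than one place, so no single step can be drawn from them. Compound 3 `CCCCCCC(Sc1nc(Cl)cc(Nc2nc(-c3ccc(OC)cc3)cs2)n1)C(=O)O` changes compound 2 by 4-methoxyphenyl in place of 2,4-difluorophenyl on an aromatic carbon. Within the data shown here, with no comparable step known, only a modest shift is expected, likely within the scatter. Compound 3 is therefore estimated at 3500 nM, with a range from 1200 nM to 10000 nM, which means an expected step of a 1.4-fold higher number from compound 2 to compound 3 (0.15 log units; within the scatter).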

Compound 3, half-maximal inhibitory concentration: 1800 nM
Beside the measured number, compound 3's estimate is 1.9-fold (0.29 log units) above it, and the stated range covers the measured number.
By their numbers in this assay, from the lowest: compounds 3 and 2 (each within the scatter of the next); then compound 1.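

In this assay, this single-place comparison gives a 1.4-fold lower number from compound 2 to compound 3 (0.14 log units; within the scatter), so on this aromatic carbon 4-methoxyphenyl can stand in place of 2,4-difluorophenyl with no step beyond the scatter. The entering group counts one hydrogen-bond acceptor and the leaving group none, yet this difference comes with no step beyond the scatter. No measurement shown accounts for this result. As far as these compounds go, whether an unsubstituted phenyl or a phenyl bearing an amine or a carboxylic acid would hold this level remains open. Compound 1 differs from the others in more than one place, so its steps cannot be read.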